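The compounds below may be only part of what the source reports. "The series", "measured", "known", "first", "only" and "open" are said of these compounds alone.

Measured compounds in an assay on U2OS cells for inhibition of secreted frizzled-related protein 1 (Homo sapiens), read by a luciferase reporter, with a stated time of 18 h; a lower number here means that less compound is needed, a higher number that more compound is needed for the effect:
Compound 1 `O=C(c1ccccc1)N1CCC(NS(=O)(=O)c2cc(S(=O)(=O)c3ccccc3)ccc2C(F)(F)F)CC1` gives 250 nM.
Compound 2 `O=C(c1cccc(Cl)c1)N1CCC(NS(=O)(=O)c2cc(S(=O)(=O)c3ccccc3)ccc2C(F)(F)F)CC1` gives 870 nM.
Compound 3 `O=C(c1ccc(Cl)cc1)N1CCC(NS(=O)(=O)c2cc(S(=O)(=O)c3ccccc3)ccc2C(F)(F)F)CC1` gives 1800 nM.

Compound 3 stands highest of the three numbers; the steps of a 2.1-fold higher number from compound 2 to compound 3 (0.32 log units; beyond the scatter) and a 7.2-fold higher number from compound 1 to compound 3 (0.86 log units; beyond the scatter) are both beyond the scatter. Compound 4 `O=C(c1ccc(C(F)(F)F)cc1)N1CCC(NS(=O)(=O)c2cc(S(=O)(=O)c3ccccc3)ccc2C(F)(F)F)CC1` differs from compound 3 by trifluoromethyl in place of chloro on an aromatic carbon. Among the measured compounds shown here, no measured pair exchanges chloro for trifluoromethyl, so nothing bears on this change directly. The nearest steps, a 7.2-fold higher number from compound 1 to compound 3 (0.86 log units; beyond the scatter) and a 3.5-fold higher number from compound 1 to compound 2 (0.54 log units; beyond the scatter), show that a substituent on this ring raises the number in this assay, and a further substituent change at the same place is not expected to reverse that. Compound 4 is therefore expected to show a step of a 1.4-fold higher number from compound 3 to compound 4 (0.14 log units; within the scatter), within or just beyond the scatter. Compound 4 is estimated at 2500 nM in this assay, range 900 nM to 7000 nM.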

Compound 4, half-maximal effective concentration: 970 nM
The estimate for compound 4 lay 2.6-fold (0.41 log units) above the measured number; measured number inside the range.
By their numbers in this assay, from the lowest: compound 1; then compounds 2, 4 and 3 (each within the scatter of the next, the first and the last beyond it).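

Trifluoromethyl in place of hydrogen on this ring gives a 3.9-fold higher number from compound 1 to compound 4 (0.59 log units; beyond the scatter) in this assay, so raising of the number at this place is not confined to chloro. The exchange of chloro for trifluoromethyl gives a 1.9-fold lower number from compound 3 to compound 4 (0.27 log units; within the scatter) and so does not separate the two groups at this place, while a 1.1-fold higher number from compound 2 to compound 4 (0.05 log units; within the scatter) likewise leaves 4-(trifluoromethyl)phenyl and 3-chlorophenyl unseparated. No measured evidence bears on these steps.

As far as these compounds go, whether a methoxy group, an amine or a carboxylic acid at this place also raises the number remains open. Also open, from the compounds shown here alone, is whether any group on this ring brings the number under that of compound 1.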